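Methyl for cyclopropyl on a sulfonyl sulfur

A few compounds are considered here, and "the series" means these few. Any claim that something is new, unique, unknown or untested is made for them only; others in the source may bear on it.

Compound 1 `CS(=O)(=O)c1cncc(-c2ccc3ncc(-c4ccc(S(=O)(=O)C5CC5)cc4)n3n2)c1` sits at a limit of a physicochemical assay for solubility, at pH 6.5; on this read-out higher numbers stand for higher solubility and lower numbers for lower solubility: it gives < 5000 nM, which is a limit and not a number (the limit of < 5000 nM in this assay, at which 1 of the 2 values shown sits). Compound 2 `CS(=O)(=O)c1ccc(-c2cnc3ccc(-c4cccc(S(=O)(=O)CCO)c4)nn23)cc1` is measured in this assay at 8600 nM. Compound 3 `CS(=O)(=O)c1ccc(-c2cnc3ccc(-c4cncc(S(C)(=O)=O)c4)nn23)cc1` differs from compound 1 by methyl in place of cyclopropyl on a sulfonyl sulfur. For the measured compounds named here, no measured pair shows this change, so no step size is known; a small step in this assay, not clearly beyond the scatter, is expected, as a step that the limit leaves unreadable from compound 1 to compound 3. Compound 3 is therefore estimated at 4000 nM in this assay, within a range of 1000 nM to 12000 nM, with a fair chance that only a limit is reported again.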

Compound 3, solubility: < 5000 nM
Compound 3 ended at the assay's limit (the forecaster's own chance of this, stated with the estimate: 50%); the middle value lies beyond the limit too.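

For the compounds shown here, compound 1 and compound 3 both stand at a limit in this assay, so no step between them can be read: the limit of < 5000 nM in this assay, at which 2 of the 3 values shown sit. From the compounds shown here alone, how far methyl in place of cyclopropyl on a sulfonyl sulfur moves this read-out stays open.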